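Swapping the aryl on the anilinomethyl chain for a carbamate

A few compounds are considered here, and "the series" means these few. Any claim that something is new, unique, unknown or untested is made for them only; others in the source may bear on it.

Three compounds have been measured in an ADME assay on A549 cells (Homo sapiens) for cytotoxicity, read by resazurin assay, with a stated time of 48 h; a higher number here means that more compound is tolerated, a lower number that less compound is tolerated:

Compound 1, `O=C(Nc1ccc(NCc2ccc(F)cc2)cc1Cl)c1cc(Cl)ccc1O`: 54400 nM
Compound 2, `O=C(Nc1ccc(NCc2ccc(Br)cc2)cc1Cl)c1cc(Cl)ccc1O`: 40900 nM
Compound 3, `CN(C)c1ccc(CNc2ccc(NC(=O)c3cc(Cl)ccc3O)c(Cl)c2)cc1`: 24500 nM

Among the measured compounds shown here, compound 3 has the lowest number of the three, yet its separation from compound 2 is only a 1.7-fold lower number from compound 2 to compound 3 (0.22 log units; within the scatter), and only the step of a 2.2-fold lower number from compound 1 to compound 3 (0.35 log units; beyond the scatter) reaches beyond the scatter. The remaining step, a 1.3-fold lower number from compound 1 to compound 2 (0.12 log units; within the scatter), is also within the scatter. All three measured steps exchange one substituent on the same aromatic ring and leave the rest of the molecule untouched.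

Compound 4, `CC(C)(C)OC(=O)NCCNc1ccc(NC(=O)c2cc(Cl)ccc2O)c(Cl)c1`, differs from compound 3 in ((tert-butoxycarbonyl)amino)methyl in place of 4-(dimethylamino)phenyl on a saturated chain carbon bound to a nitrogen on an aromatic ring. Here the aromatic ring itself departs and an open chain carrying a carbamate enters, a change of a different kind from any step measured so far, so the measured steps bear on it only loosely. Since those steps were small and the numbers of compounds 1 to 3 sit close together, no step beyond the scatter is expected for compound 4 in this assay, with any drift if present toward a higher number. The expected step is a 1.4-fold higher number from compound 3 to compound 4 (0.15 log units; within the scatter). Compound 4 is therefore estimated at 35000 nM, with a range from 15000 nM to 80000 nM.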

Compound 4, half-maximal cytotoxic concentration: 25000 nM
Estimate against measurement, compound 4: 1.4-fold (0.15 log units) above; measured number inside the range.
By their numbers in this assay, from the lowest: compounds 3, 4, 2 and 1 (each within the scatter of the next, the first and the last beyond it).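

At this position, on a saturated chain carbon bound to a nitrogen on an aromatic ring, the aromatic ring can give way to an open chain with no step beyond the scatter in this assay: ((tert-butoxycarbonyl)amino)methyl in place of 4-(dimethylamino)phenyl reads (a 1.0-fold higher number from compound 3 to compound 4 (0.01 log units; within the scatter)), and in place of 4-bromophenyl it reads (a 1.6-fold lower number from compound 2 to compound 4 (0.21 log units; within the scatter)). Only the exchange for 4-fluorophenyl goes beyond the scatter (a 2.2-fold lower number from compound 1 to compound 4 (0.34 log units; beyond the scatter)), so compound 1 stands apart from compound 4 just as it does from compound 3. Nothing measured here offers an explanation for these numbers.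

The compounds shown leave open whether the carbamate itself counts or any open chain would serve. A free amine or a carboxylic acid at the chain end, or a longer chain, would begin to separate the two.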